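The source may report more compounds than this note shows. Statements on the series, on what has been measured and on what is new or still open speak of the compounds shown alone.

Compound 1 (`COc1cccc2sc(-c3ccc(N)c(Cl)c3)nc12`) gives in a functional assay on MCF7 cells (Homo sapiens) for inhibition (a higher number here means a weaker inhibitor, a lower number a stronger inhibitor), a reading that is only a limit of the assay, > 10000 nM. Compound 2 (`c1ccc2sc(-c3ccc(N4CCCC4)cc3)nc2c1`) likewise returns a limit in this assay, < 1000 nM, so compound 2 stands at the limit of < 1000 nM in this assay, at which 1 of the 2 values shown sits, with no number beneath it. Compound 3 (`c1ccc2sc(-c3ccc(N4CCCCC4)cc3)nc2c1`) is not yet measured and differs from compound 2 by piperidin-1-yl in place of pyrrolidin-1-yl on an aromatic carbon. For the measured compounds named here, no measured step of this kind is available, so the step is expected to be small and without a set direction, within the scatter or close to it: a step that the limit leaves unreadable from compound 2 to compound 3. Compound 3 is expected to give about 600 nM in this assay, estimated between 100 nM and 3000 nM.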

Compound 3, half-maximal inhibitory concentration: > 10000 nM
Compound 3: a limit, no number; the forecaster's own chance of this, stated with the estimate: 40%; at least 16-fold (1.22 log units) between middle value and limit.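

Piperidin-1-yl in place of pyrrolidin-1-yl on the aromatic carbon gives an at least 10-fold higher number from compound 2 to compound 3 (1.00 log units; beyond the scatter) in this assay. This position is therefore not indifferent to the change from a five-membered to a six-membered non-aromatic ring, even though both groups have the same hydrogen-bond counts and no net charge. Both ends of the step are limits of the assay, so the real size of the step stays unread: the limit of > 10000 nM in this assay, at which 2 of the 3 values shown sit.

No compound shown has an exact value. Still open, on these data alone, is how a morpholin-4-yl or a dimethylamino group would read at this position on the same core.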